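The source may hold more compounds than are shown below. What is called first, only, known or untested is meant among the compounds shown, and "the series" means these compounds.

Measured compounds:
- compound 1 `Nc1cc(N)c2nc(-c3ccccc3)c(NCc3ccc(Cl)c(Cl)c3)nc2c1` gives in a functional assay on NCI-H226 cells (Homo sapiens) for inhibition, read by sulforhodamine B assay, with a stated time of 48 h (a higher number here means that more compound is tolerated, a lower number that less compound is tolerated), the value 95500 nM.
- compound 2 `COc1cc(CNc2nc3cc(N)cc(N)c3nc2-c2ccccc2)cc(OC)c1OC` gives in this assay only a limit, < 50200 nM.
- compound 3 `CCOC(=O)[C@H](CCC(=O)O)NC(=O)c1ccc(Oc2nc3cc(N)cc(N)c3nc2-c2ccccc2)cc1` gives in this assay only a limit, < 100000 nM.

For the measured compounds named here, compound 1 is the only member of this set with a plain number in this assay; the other two results are limits of the assay and not numbers, namely the limit of < 50200 nM in this assay, at which 1 of the 3 values shown sits, and (the limit of < 100000 nM in this assay, at which 1 of the 3 values shown sits). Going by the values given here, no two measured compounds differ in just one place, so no measured step is available to calibrate a change of this kind.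

Compound 4 `COc1ccc(CNc2nc3cc(N)cc(N)c3nc2-c2ccccc2)cc1` differs from compound 1 in one place: 4-methoxyphenyl in place of 3,4-dichlorophenyl on a saturated chain carbon bound to a nitrogen on an aromatic ring. The shared core, its phenyl group and its two amino groups are unchanged, and the group that leaves and the group that enters each carry one six-membered aromatic ring of carbon only.

Among the compounds with values here, with no measured step to lean on, the change from compound 1 to compound 4 is expected to produce no shift beyond the usual scatter, so the step of a 1.2-fold lower number from compound 1 to compound 4 (0.08 log units; within the scatter) is estimated as roughly flat. For compound 4 the expected value in this assay is 80000 nM, with a range from 30000 nM to 200000 nM.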

Compound 4, concentration lethal to 50% of the cells: < 100000 nM
Compound 4: a limit, no number; the forecaster's own chance of this, stated with the estimate: 35%; the middle value does not contradict the limit.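

In this assay, compound 4 gives < 100000 nM, which is a limit of the assay and not a number. For the compounds shown here, no step can therefore be read from compound 1 to compound 4. The compounds shown leave open whether 4-methoxyphenyl in place of 3,4-dichlorophenyl changes the value in this assay at all, and in which direction.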